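A few compounds are considered here, and "the series" means these few. Any claim that something is new, unique, unknown or untested is made for them only; others in the source may bear on it.

Compound 1, `COc1ccc(C(=O)O)cc1-c1cccc(COc2ccc3c(c2)CN(C2CCCC2)C3=O)c1`: 80 nM in an assay on HEK293 cells for positive allosteric modulation of metabotropic glutamate receptor 2 (Rattus norvegicus), read by thallium flux; a higher number here means that more compound is needed for the effect, a lower number that less compound is needed
Compound 2, `O=C(O)c1cc(-c2cccc(COc3ccc4c(=O)n(C5CCC5)sc4c3)c2)ccc1Cl`: 580 nM in this assay

Of the two measured compounds, compound 1 has the lower number in this assay; compound 2 sits higher, and the gap between them lies beyond the usual scatter. Going by the values given here, no step between compounds differing in a single place has been measured, so the series gives no direct guide to the change now in question.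

Compound 3, `COc1ccc(-c2cccc(COc3ccc4c(c3)CN(C3CCCC3)C4=O)c2)cc1C(=O)O`, keeps every atom of compound 1 but joins them differently: 3-carboxy-4-methoxyphenyl in place of 5-carboxy-2-methoxyphenyl on an aromatic carbon, the new group sitting on an aromatic carbon of a six-membered aromatic ring of carbon only, meta to a large group. Moving the carboxy and methoxy groups around that ring is a change whose effect nothing in the measured pair fixes, so the expectation stays loose. The expected step of a 3.1-fold higher number from compound 1 to compound 3 (0.49 log units; beyond the scatter) is a moderate move toward a higher number, though one that might still fall within the scatter. Compound 3 is therefore estimated at 250 nM, with a range from 60 nM to 1000 nM.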

Compound 3, half-maximal effective concentration: 170 nM
Beside the measured number, compound 3's estimate is 1.5-fold (0.17 log units) above it, and the stated range covers the measured number.
By their numbers in this assay, from the lowest: compound 1; then compound 3; then compound 2.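

In this assay, going by these compounds alone, 3-carboxy-4-methoxyphenyl in place of 5-carboxy-2-methoxyphenyl on the aromatic carbon gives a 2.1-fold higher number from compound 1 to compound 3 (0.33 log units; beyond the scatter), the first step between compounds that differ in one place. The atoms stay the same, so the arrangement of these groups on the ring is enough to shift the number, here modestly, and compound 1 keeps the lower number of the pair. Nothing available accounts for the size or direction of this shift.

On these data alone, the carboxy and methoxy groups moved together, and the effect of each alone remains open, as does what an ethoxy group or a tetrazole would do on this ring. As far as these compounds go, it also remains open whether the same rearrangement would give a similar step on the core of compound 2.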